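The source may hold more compounds than are shown below. What is called first, only, known or untested is meant among the compounds shown, and "the series" means these compounds.

Measured compounds in an ADME assay on cells (Hepatocyte, Homo sapiens) for metabolic stability, with a stated time of 30 min; on this read-out lower numbers stand for a less stable compound and higher numbers for a more stable compound:
- compound 1, `Nc1cc(C(F)(F)F)cc2c(=O)cc(N3CCN(CC4CCC(O)CC4)CC3)sc12`, 72.9%
- compound 2, `O=C(OC1CCC(CN2CCN(c3cc(=O)c4cc(C(F)(F)F)cc([N+](=O)[O-])c4s3)CC2)CC1)c1cccs1`, 2.2%
- compound 3, `O=C(OC1CCC(CN2CCN(c3cc(=O)c4cc(C(F)(F)F)cc([N+](=O)[O-])c4s3)CC2)CC1)c1ccc(C(F)(F)F)cc1`, 5.2%

Compound 2 stands lowest of the three numbers in this assay. Its nearest neighbour is compound 3, reached by the step of a number 3 percentage points higher from compound 2 to compound 3 (within the scatter). Its furthest neighbour is compound 1, whose value lies far beyond the scatter above it.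

Compound 4, `O=c1cc(N2CCN(CC3CCCCC3)CC2)sc2c([N+](=O)[O-])cc(C(F)(F)F)cc12`, is not yet measured. It differs from compound 2 in one place: hydrogen in place of ((thiophen-2-yl)carbonyl)oxy on a saturated ring carbon.

Within the data shown here, no measured step matches this change. Among the measured compounds shown here, the one step on record, from compound 2 to compound 3, only exchanges the group on the carbonyl carbon and stays within the scatter, so it says little about removing the whole ((thiophen-2-yl)carbonyl)oxy group. Compound 1, which carries neither that group nor the nitro group, gives a much higher number, but it differs from compound 2 in two places, so its high value cannot be pinned on one of them. The expectation for compound 4 is therefore uncertain, with a step of a number 32.8 percentage points higher from compound 2 to compound 4 (beyond the scatter) expected upward but wide. Compound 4 is estimated at 35%, within a range from 8% to 72%.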

Compound 4, percent of the compound remaining: 82.4%
Estimate against measurement, compound 4: 47.4 percentage points below; measured number above the stated range.
By their numbers in this assay, from the lowest: compounds 2 and 3 (each within the scatter of the next); then compounds 1 and 4 (each within the scatter of the next).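

In this assay, putting hydrogen in place of ((thiophen-2-yl)carbonyl)oxy on the saturated ring carbon gives a number 80.2 percentage points higher from compound 2 to compound 4 (beyond the scatter), so this position can move the read-out by a large amount. The earlier step, a number 3 percentage points higher from compound 2 to compound 3 (within the scatter), exchanged only the group on the carbonyl carbon and could not show this: the read-out responds strongly to removing the whole group, not to that exchange. No measurement shown gives a reason for the size of the new step.

As far as these compounds go, it remains open whether the entire group must go or whether a smaller part of it accounts for the step. A methoxy group, a carboxylic acid or an amide-linked thiophene on the same ring carbon, with the rest of compound 4 unchanged, would help to separate these possibilities.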